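This account rests on a few compounds, and the source may have more. Where it says the series, first, only, none or still open, it means among the compounds named here.

Within the data shown here, in a physicochemical assay for lipophilicity, at pH 7.4 (on this read-out lower numbers stand for lower lipophilicity and higher numbers for higher lipophilicity), compound 1 (`N#Cc1ccc(O[C@H]2CN(S(=O)(=O)c3ccc(C(F)(F)F)cc3)C[C@@]2(O)CO)cc1F`) gives 4.5 as the highest of the three numbers so far. Compound 2 (`N#Cc1ccc(O[C@H]2CN(S(=O)(=O)c3ccc(Cl)cc3Cl)C[C@@]2(O)CN)cc1F`) stands lower at 4 and compound 3 (`N#Cc1ccc(S(=O)(=O)[C@H]2CN(S(=O)(=O)c3ccc(Cl)cn3)C[C@@]2(O)CO)cc1`) lower again at 3.1 with both gaps to compound 1 beyond the scatter. Compound 4 (`N#Cc1ccc(O[C@H]2CN(S(=O)(=O)c3ccc(Cl)cc3)C[C@@]2(O)CO)cc1F`) has no number yet. It differs from compound 1 by chloro in place of trifluoromethyl on an aromatic carbon, para to a large group (chloro in place of trifluoromethyl on an aromatic carbon). Among the measured compounds shown here, no measured pair isolates a single change, so the expectation rests on this structural change alone. The expected step of a number 0.20 log units lower from compound 1 to compound 4 (within the scatter) is a small fall in this assay that stays within the scatter. Compound 4 is estimated at 4.3 with an expected range from 3.9 to 4.6 as its bounds.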

Compound 4, distribution coefficient: 4.1
Estimate against measurement, compound 4: 0.20 log units above, and the stated range covers the measured number.
By their numbers in this assay, from the lowest: compound 3; then compounds 2 and 4 (each within the scatter of the next); then compound 1.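

In this assay, among these compounds, 4-(trifluoromethyl)phenyl to 4-chlorophenyl gives the first single-change comparison, and it reads as a number 0.40 log units lower from compound 1 to compound 4 (beyond the scatter), a modest step. The place on the aromatic carbon therefore responds to this exchange, with the rest of the structure held constant. Nothing available here accounts for the size of the step.

Where a methoxy group or a dimethylamino group in the same place would fall in this assay remains open. From the compounds shown here alone, whether the same exchange gives a similar step with other groups elsewhere on the core also remains open.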